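Adding a Third Methoxy Group: Compound 2 to Compound 3

The source may hold more compounds than are shown below. What is called first, only, known or untested is meant among the compounds shown, and "the series" means these compounds.

Measured compounds:
Compound 1 `Cc1cc(O)c(C2=NN(c3ccc(S(N)(=O)=O)cc3)C(c3ccccc3O)C2)cc1Cl`: 1760 nM
Compound 2 `COc1ccc(C2CC(c3cc(Cl)c(C)cc3O)=NN2c2ccc(S(N)(=O)=O)cc2)cc1OC`: 2610 nM

In a functional assay on M14 cells (Homo sapiens) for antiproliferative activity, with a stated time of 48 h (on this read-out higher numbers stand for weaker inhibition of growth and lower numbers for stronger inhibition of growth), compound 1 gives 1760 nM and compound 2 gives 2610 nM. Going by the values given here, the only measured step, a 1.5-fold higher number from compound 1 to compound 2 (0.17 log units; within the scatter), lies within the scatter, so compound 2 and compound 1 cannot be told apart on these numbers. Compound 3 `COc1ccc(C2CC(c3cc(Cl)c(C)cc3O)=NN2c2ccc(S(N)(=O)=O)cc2)c(OC)c1OC` differs from compound 2 by methoxy in place of hydrogen on an aromatic carbon. Among the compounds with values here, no measured step adds a methoxy group to this ring; the one step available swapped a whole substituent and stayed within the scatter. No shift beyond the scatter is therefore expected. Compound 3 is estimated at 2600 nM, ranging from 1000 nM to 6500 nM, which means a 1.0-fold lower number from compound 2 to compound 3 (0.00 log units; within the scatter).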

Compound 3, concentration for 50% growth inhibition: 2020 nM
Compound 3: the middle estimate sits 1.3-fold (0.11 log units) above what was measured; the measured number falls inside the stated range.
By their numbers in this assay, from the lowest: compounds 1, 3 and 2 (each within the scatter of the next).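

In this assay, methoxy on this aromatic carbon, ortho to a large group, gives a 1.3-fold lower number from compound 2 to compound 3 (0.11 log units; within the scatter) and so leaves no shift that can be told apart from repeat measurements. The larger swap on the saturated ring carbon gives a 1.1-fold higher number from compound 1 to compound 3 (0.06 log units; within the scatter) and likewise separates 2,3,4-trimethoxyphenyl from 2-hydroxyphenyl by no readable margin. Nothing available explains why these numbers stay so close. Going by these compounds, whether an amine or a carboxylic acid on this aromatic carbon would move the number remains open. So does the effect of a longer chain in place of methoxy.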